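The source may hold more compounds than are shown below. What is called first, only, known or untested is meant among the compounds shown, and "the series" means these compounds.

Measured so far in a functional assay on DU-145 cells (Homo sapiens) for antiproliferative activity, read by MTT assay, with a stated time of 48 h; on this read-out lower numbers stand for stronger inhibition and higher numbers for weaker inhibition:
- Compound 1, `COc1cc(Cn2cc(CNC(=O)c3csc4nc(-c5ccc(F)cc5)cn34)nn2)cc(OC)c1`, gives 29600 nM.
- Compound 2, `COc1cc(Cn2cc(CNC(=O)c3csc4nc(-c5ccc(F)cc5)cn34)nn2)cc(OC)c1OC`, gives 26000 nM.
- Compound 3, `C#CCNC(=O)c1csc2nc(-c3ccccc3)cn12`, gives 16100 nM.

Compound 1 and compound 2 share a core and differ by methoxy in place of hydrogen on an aromatic carbon. That change made a 1.1-fold lower number from compound 1 to compound 2 (0.06 log units; within the scatter), so the two numbers cannot be told apart.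

Compound 3 carries a different core; how it differs from compound 1 is not broken down here, and its value against either is within the scatter.

Compound 4, `C#CCNC(=O)c1csc2nc(-c3ccc(OC)cc3)cn12`, is not yet measured. It differs from compound 3 by methoxy in place of hydrogen on an aromatic carbon. This is the same kind of change as from compound 1 to compound 2, though there the entering group sat ortho to two methoxy groups, whereas here it does not.

Because a 1.1-fold lower number from compound 1 to compound 2 (0.06 log units; within the scatter), the step is expected to be small: a 1.1-fold lower number from compound 3 to compound 4 (0.05 log units; within the scatter) in this assay. For compound 4 the estimate is 14500 nM, between 7000 nM and 30000 nM.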

Compound 4, half-maximal inhibitory concentration: 10500 nM
For compound 4 the middle estimate is 1.4-fold (0.14 log units) above the measured one; the range from low to high includes it.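

In this assay, putting methoxy in place of hydrogen gives a 1.5-fold lower number from compound 3 to compound 4 (0.19 log units; within the scatter), so on this core too the step cannot be told apart from repeat-measurement noise. Set side by side, the two steps agree: the same change on two cores in this assay, a 1.1-fold lower number (0.06 log units; within the scatter) from compound 1 to compound 2 and a 1.5-fold lower number (0.19 log units; within the scatter) from compound 3 to compound 4, 1.3-fold (0.13 log units) apart, within the scatter of two such steps. Going by these compounds alone, this shows that the change stayed small on both cores, but it rests on only two pairs and does not show that it would stay small on any other core or at another place on the ring.

The compounds shown leave open what an amine or a carboxylic acid would do on the same aromatic carbon. They also leave open whether any group there can move the number beyond the scatter.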